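The source may report more compounds than this note shows. Statements on the series, on what has been measured and on what is new or still open speak of the compounds shown alone.

In a physicochemical assay for lipophilicity, read by HPLC, tested at 5 mM (on this read-out lower numbers stand for lower lipophilicity and higher numbers for higher lipophilicity), compound 1 (`CCCCCCCCc1ccc(OCC(=O)Cn2nnc(-c3ccc(Cl)cc3)n2)cc1`) gives > 8, which is a limit of the assay and not a number. Compound 2 (`CCCCCCCCc1ccc(OC(C)C(=O)Cn2nnc(-c3ccccc3)n2)cc1`) gives > 8, again only a limit, so it offers no exact starting point. Compound 3 (`CC(Oc1ccc(-c2ccccc2)cc1)C(=O)Cn1nnc(-c2ccccc2)n1`) has phenyl in place of octyl on an aromatic carbon, para to a large group: phenyl in place of octyl on an aromatic carbon. Among the compounds with values here, no measured pair shows this change, so the size of the step rests on expectation alone. A clear fall in this assay is expected, with the estimated step being a number at least 2.20 log units lower from compound 2 to compound 3 (beyond the scatter). For compound 3, the expected value is 5.8, within an estimated range of 5 to 6.8.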

Compound 3, partition coefficient: 5.3
Estimate against measurement, compound 3: 0.50 log units above, within the range that was stated.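

In this assay, phenyl in place of octyl on an aromatic carbon, para to a large group, gives a clear fall: a number at least 2.70 log units lower from compound 2 to compound 3 (beyond the scatter). Compound 3 thus brings the series its first reading that is a number, and shows that a change at this position can bring the read-out down from the limit. The true size of the step stays unknown because compound 2 gives only a limit of the assay: the limit of > 8 in this assay, at which 2 of the 3 values shown sit.

Where a butyl chain, an amine or a carboxylic acid at this position would fall in this assay remains open. So does whether the same change would give a like step on the core of compound 1.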